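Swapping 4-methoxyphenyl for 2,3-dimethoxyphenyl on compound 2

The source may hold more compounds than are shown below. What is called first, only, known or untested is meant among the compounds shown, and "the series" means these compounds.

In a functional assay on Ehrlich cells (Mus musculus) for cytotoxicity, with a stated time of 48 h (on this read-out lower numbers stand for stronger inhibition of growth and higher numbers for weaker inhibition of growth), compound 1 (`Nc1nc(OC[C@H]2CCC(=O)N2)c2nc[nH]c2n1`) gives 18000 nM and compound 2 (`COc1ccc(/C=N/c2c(C#N)nc(=O)[nH]c2NS(=O)(=O)c2ccc(C)cc2)cc1`) gives 17000 nM on the same read-out. These two numbers lie within the usual scatter of each other, so compound 2 stands level with compound 1 and neither can be ranked. For the measured compounds named here, no measured pair differs in one place, so the data offer no step to serve as a guide. Compound 3 (`COc1cccc(/C=N/c2c(C#N)nc(=O)[nH]c2NS(=O)(=O)c2ccc(C)cc2)c1OC`) keeps the core of compound 2 but carries 2,3-dimethoxyphenyl in place of 4-methoxyphenyl on a carbon with a double bond to nitrogen. With compound 2 at 17000 nM as the starting point, no shift beyond the scatter is expected in this assay and no direction is favoured. The expected change is small, with a 1.1-fold lower number from compound 2 to compound 3 (0.05 log units; within the scatter) as the estimated step. For compound 3 the estimate is 15000 nM with an expected range from 6000 nM to 40000 nM as the likely span.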

Compound 3, concentration for 50% growth inhibition: 21000 nM
Estimate against measurement, compound 3: 1.4-fold (0.15 log units) below; the measured number falls inside the stated range.
By their numbers in this assay, from the lowest: compounds 2, 1 and 3 (each within the scatter of the next).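

In this assay, 2,3-dimethoxyphenyl in place of 4-methoxyphenyl on a carbon with a double bond to nitrogen leaves compound 3 level with compound 2 (a 1.2-fold higher number from compound 2 to compound 3 (0.09 log units; within the scatter)). For the compounds shown here, this is the first single-place step available, and it shows that this exchange at this position, which brings in one more oxygen and one more hydrogen-bond acceptor, does not move the number beyond the scatter. No measured evidence bears on why the read-out stays level.

From the compounds shown here alone, whether an amine or a carboxylic acid on the ring at this position would shift growth inhibition beyond the scatter remains open. Going by these compounds, it is equally open whether a change anywhere else on the shared core of compound 2 and compound 3 would do so.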